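The source may report more compounds than this note shows. Statements on the series, on what has been measured and on what is new or still open speak of the compounds shown alone.

Three compounds have been measured in a functional assay on the whole organism for inhibition, with Rattus norvegicus as the target, read by paw edema, with stated times of 4 days, 1 h and 2 h, at a dose of 100 mg/kg by the oral route; on this read-out lower numbers stand for less inhibition and higher numbers for more inhibition at the one dose given (going by the name of the read-out):

Compound 1, `CC1CCN(c2nc(-c3ccccc3)nc3ccc(I)cc23)CC1`, gives 56.4%.
Compound 2, `Ic1ccc2nc(-c3ccccc3)nc(N3CCC(c4ccccc4)CC3)c2c1`, gives 82.5%.
Compound 3, `CC1CCN(c2nc(-c3ccc(Cl)cc3)nc3ccc(Br)cc23)CC1`, gives 55.1%.

Compound 2 differs from compound 1 in one place, (phenyl in place of methyl on a saturated ring carbon), and this change made a step of a number 26.1 percentage points higher from compound 1 to compound 2 (beyond the scatter). Compound 3 is built on a different core from compound 1, and the difference between the two cores is not broken down here; the values of compound 3 and compound 1 in this assay lie within the scatter of one another.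

Compound 4, `Clc1ccc(-c2nc(N3CCC(c4ccccc4)CC3)c3cc(Br)ccc3n2)cc1`, has not yet been measured. It differs from compound 3 in one place, (phenyl in place of methyl on a saturated ring carbon), at a place described in exactly the same words as for the change from compound 1 to compound 2, so it is the same change made on the core of compound 3. A step of similar size is expected from compound 3 to compound 4, about a number 22.9 percentage points higher from compound 3 to compound 4 (beyond the scatter), because the same change gave a number 26.1 percentage points higher from compound 1 to compound 2 (beyond the scatter). The expected value for compound 4 is therefore 78%, most likely between 62% and 90%.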

Compound 4, a percentage reported as inhibition, in the whole organism at one dose (the size of the read-out at that dose, not a potency): 50%
Compound 4: middle estimate off by 28 percentage points, on the high side, outside the stated range (below it).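

In this assay, putting phenyl in place of methyl on the saturated ring carbon gave a number 5.1 percentage points lower from compound 3 to compound 4 (within the scatter), so the gain seen on the core of compound 1 did not carry over to the core of compound 3: the same change on two cores in this assay, a number 26.1 percentage points higher (beyond the scatter) from compound 1 to compound 2 and a number 5.1 percentage points lower (within the scatter) from compound 3 to compound 4, 31.2 percentage points apart, beyond the scatter of two such steps For these two pairs, the result of the change depends on the core that carries it, and a step measured on one core cannot simply be added to a compound on another. This does not show which part of the difference between the two cores is responsible, and two pairs are too few to set a rule for the whole series.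

The compounds shown carry only methyl or phenyl on this ring carbon, leaving open how a longer chain, an amine or a carboxylic acid would behave there on either core. On these data alone, it also remains open whether a core carrying only part of the difference between the two cores would respond as compound 2 does or as compound 4 does.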